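The source may hold more compounds than are shown below. What is called first, only, known or untested is meant among the compounds shown, and "the series" means these compounds.

Of the compounds shown here, two have been measured in a functional assay on T47D cells (Homo sapiens) for inhibition; a lower number here means a stronger inhibitor, a higher number a weaker inhibitor. Compound 1 `Oc1cccc(-c2cc(-c3cccc(F)c3)cc(-c3cccc(O)c3)n2)c1` gives 21300 nM there, while compound 2 `Oc1cccc(-c2cc(-c3cccc(OC(F)(F)F)c3)cc(-c3ccccc3O)n2)c1` gives 5390 nM, the lower of the two numbers, with compound 1 standing well beyond the scatter above it. Compound 3 `Oc1cccc(-c2cc(-c3cccc(OC(F)(F)F)c3)cc(-c3cccc(O)c3)n2)c1` has not been measured; it differs from compound 2 by 3-hydroxyphenyl in place of 2-hydroxyphenyl on an aromatic carbon, the two sharing the same atoms joined differently. Going by the values given here, no measured pair shows this change on its own, so little guides its size. Compound 3 is expected to sit near compound 2, with a small step of a 1.5-fold higher number from compound 2 to compound 3 (0.17 log units; within the scatter) that may lie within the scatter. The estimate for compound 3 is 8000 nM, within 2500 nM to 25000 nM.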

Compound 3, half-maximal inhibitory concentration: 6740 nM
Estimate against measurement, compound 3: 1.2-fold (0.07 log units) above; the range from low to high includes it.
By their numbers in this assay, from the lowest: compounds 2 and 3 (each within the scatter of the next); then compound 1.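

In this assay, 3-hydroxyphenyl in place of 2-hydroxyphenyl next to the ring nitrogen gives a 1.3-fold higher number from compound 2 to compound 3 (0.10 log units; within the scatter) and so does not separate the two compounds. Compound 3 also allows trifluoromethoxy in place of fluoro to be read on its own, with a 3.2-fold lower number from compound 1 to compound 3 (0.50 log units; beyond the scatter) on that change. No supporting data bear on why either step has the size it does.

On these data alone, it remains open whether an aminophenyl or methoxyphenyl group at this place would behave like the two hydroxyphenyl groups. As far as these compounds go, how chloro or trifluoromethyl would compare with fluoro and trifluoromethoxy also remains open.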